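A few compounds are considered here, and "the series" means these few. Any claim that something is new, unique, unknown or untested is made for them only; others in the source may bear on it.

In a functional assay on NCI-H1993 cells (Homo sapiens) for inhibition, read by CCK-8 assay, with a stated time of 72 h (on this read-out lower numbers stand for stronger inhibition and higher numbers for weaker inhibition), compound 1 (`CC(c1c(F)cc2ncccc2c1F)n1cnc2ncc(-c3cnn(C)c3)nc21`) gives 35.5 nM, compound 2 (`CC(c1c(F)cc2ncccc2c1F)n1cnc2ncc(-c3cnn(CCO)c3)nc21`) gives 83.7 nM and compound 3 (`CC(c1cc2cccnc2cc1F)n1cnc2ncc(-c3ccncc3)nc21`) gives 171 nM. Compound 3 therefore has the highest of the three numbers, and its gaps to the other two lie beyond the scatter.

Compound 4 (`CC(c1c(F)cc2ncccc2c1F)n1cnc2ncc(-c3ccncc3)nc21`) has one change from compound 3: fluoro in place of hydrogen on an aromatic carbon. This is fluoro in place of hydrogen on an aromatic carbon.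

Among the measured compounds shown here, no measured step covers this change. For the measured compounds named here, the only single-change step is a 2.4-fold higher number from compound 1 to compound 2 (0.37 log units; beyond the scatter), which is modest, lies at another place in the molecule and involves hydroxymethyl rather than fluoro. It gives only a rough scale for one change in this series. Compound 1 and compound 2 already carry the fluoro in question, and both have lower numbers than compound 3, but they also differ from compound 3 in a second place. That comparison cannot isolate the fluoro, so it gives only weak support for the direction.

The step expected is a 1.6-fold lower number from compound 3 to compound 4 (0.19 log units; within the scatter), a small move to a lower number that may stay within the scatter. For compound 4 the estimated value in this assay is 110 nM, with an expected range from 45 nM to 270 nM.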

Compound 4, half-maximal inhibitory concentration: 162 nM
Compound 4: the middle estimate sits 1.5-fold (0.17 log units) below what was measured; the measured number falls inside the stated range.
By their numbers in this assay, from the lowest: compound 1; then compounds 2, 4 and 3 (each within the scatter of the next, the first and the last beyond it).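

In this assay, fluoro in place of hydrogen on an aromatic carbon, ortho to a fused ring and ortho to a large group, gives a 1.1-fold lower number from compound 3 to compound 4 (0.02 log units; within the scatter), so with pyridin-4-yl on the core this position shows no readable effect of fluoro. With that fluoro held constant, the aromatic group on the other side of the molecule can now be read alone: pyridin-4-yl in place of 1-methyl-1H-pyrazol-4-yl gives a 4.6-fold higher number from compound 1 to compound 4 (0.66 log units; beyond the scatter), the only one of the three new steps beyond the scatter, while pyridin-4-yl in place of 1-(2-hydroxyethyl)-1H-pyrazol-4-yl gives a 1.9-fold higher number from compound 2 to compound 4 (0.29 log units; within the scatter). Nothing at hand bears on why these steps have these sizes.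

On these data alone, whether the fluoro step would read the same with 1-methyl-1H-pyrazol-4-yl on the core stays open, as compound 1 has no partner here carrying hydrogen at this position. Also open, as far as these compounds go, is how a chain ending in an amine or a carboxylic acid in place of the 2-hydroxyethyl chain of compound 2, or chloro or methoxy in place of this fluoro, would read in this assay.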